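Aryl urea series: chain growth on the anilide ring

This account rests on a few compounds, and the source may have more. Where it says the series, first, only, none or still open, it means among the compounds named here.

Measured so far:
Compound 1, `Cc1ccc(NC(=O)N[C@@H](C)c2ccccc2)cc1`: 100%
Compound 2, `CCc1cccc(NC(=O)N[C@H](C)c2ccccc2)c1`: 36%
Compound 3, `CCc1ccc(NC(=O)N[C@@H](C)c2ccccc2)cc1`: 91%

In an ADME assay on the whole organism with Oryza sativa as the target, tested at 10 uM (a lower number here means a stronger effect, a higher number a weaker effect of the compound at the concentration tested), compound 1 gives 100% and compound 3 gives 91%; the change between them is methyl in place of hydrogen on a saturated chain carbon bound to an aromatic carbon, and the step is a number 9 percentage points lower from compound 1 to compound 3 (within the scatter). Compound 2 gives 36% in this assay, the lowest of the three, beyond the scatter from both others. The difference between the core of compound 2 and the core of compound 1 is not broken down here.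

Compound 4, `CC(C)c1cccc(NC(=O)N[C@H](C)c2ccccc2)c1`, is not yet measured. It differs from compound 2 by methyl in place of hydrogen on a saturated chain carbon bound to an aromatic carbon and a saturated chain carbon. This is the same kind of change as from compound 1 to compound 3, though not the same: the carbon carrying the new methyl is also bound to a saturated chain carbon. Compound 4 is expected to sit near compound 2, a step of a number 4 percentage points lower from compound 2 to compound 4 (within the scatter), because a number 9 percentage points lower from compound 1 to compound 3 (within the scatter) was within the scatter. The estimate for compound 4 in this assay is 32%, between 12% and 60%.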

Compound 4, a percentage reported as activity, at one concentration (the size of the read-out at that concentration, not a potency): 44%
The estimate for compound 4 lay 12 percentage points below the measured number; low and high end bracket the measured number.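

In this assay the new step reads a number 8 percentage points higher from compound 2 to compound 4 (within the scatter) and so stays small on the core of compound 2, as the earlier step did on the core of compound 1. Even so, the two steps do not agree closely enough to be carried over as one number: the same change on two cores in this assay, a number 9 percentage points lower (within the scatter) from compound 1 to compound 3 and a number 8 percentage points higher (within the scatter) from compound 2 to compound 4, 17 percentage points apart, beyond the scatter of two such steps. Two pairs show no rule for the series, and they do not show what lies behind the gap between the steps.

Open, going by these compounds, is how a longer chain, an amine or a carboxylic acid in place of the ethyl of compound 2 would read in this assay. Also open is which part of the difference between the two cores accounts for the gap in their read-outs.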